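A Carbonyl Side-Chain Swap Among Closely Matched Compounds

A few compounds are considered here, and "the series" means these few. Any claim that something is new, unique, unknown or untested is made for them only; others in the source may bear on it.

In a functional assay on U-87MG ATCC cells (Homo sapiens) for antiproliferative activity (on this read-out lower numbers stand for stronger inhibition and higher numbers for weaker inhibition), compound 1 (`Cc1c2c(n3c1CCNC[C@@H](C)[C@H](C)Nc1cc-3ccc1C(N)=O)CC(C)(C)CC2=O`) gives 40 nM, and it carries a hydrogen on an amine nitrogen in a ring. With (2-methoxyethyl)carbonyl on that nitrogen, compound 2 (`COCCC(=O)N1CCc2c(C)c3c(n2-c2ccc(C(N)=O)c(c2)N[C@@H](C)[C@H](C)C1)CC(C)(C)CC3=O`) gives 54 nM. With (1-amino-1-methylethyl)carbonyl there, compound 3 (`Cc1c2c(n3c1CCN(C(=O)C(C)(C)N)C[C@@H](C)[C@H](C)Nc1cc-3ccc1C(N)=O)CC(C)(C)CC2=O`) gives 39 nM. Compound 3 therefore stands within the usual scatter of both other compounds, and the three cannot be ranked.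

Compound 4 (`Cc1c2c(n3c1CCN(C(=O)[C@H](C)O)C[C@@H](C)[C@H](C)Nc1cc-3ccc1C(N)=O)CC(C)(C)CC2=O`) has 1-hydroxyethyl in place of 1-amino-1-methylethyl on a carbonyl carbon. For the measured compounds named here, three measured steps bear on this change. Adding a group to the nitrogen gave a 1.4-fold higher number from compound 1 to compound 2 (0.13 log units; within the scatter) in one case and a 1.0-fold lower number from compound 1 to compound 3 (0.01 log units; within the scatter) in the other. Going by the values given here, exchanging one group on the carbonyl carbon for another, the closest precedent, gave a 1.4-fold lower number from compound 2 to compound 3 (0.14 log units; within the scatter). Among the compounds with values here, all three lie within the scatter, although they rest on only three compounds and none of them carries 1-hydroxyethyl. No step beyond the scatter is therefore expected in this assay, and the estimated change is a 1.2-fold higher number from compound 3 to compound 4 (0.06 log units; within the scatter). For compound 4, the expected value is 45 nM, with an estimated range of 20 nM to 100 nM.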

Compound 4, half-maximal inhibitory concentration: 88 nM
For compound 4 the middle estimate is 2.0-fold (0.29 log units) below the measured one; measured number inside the range.
By their numbers in this assay, from the lowest: compounds 3, 1, 2 and 4 (each within the scatter of the next, the first and the last beyond it).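

In this assay, for the compounds shown here, the groups on this nitrogen had so far stayed within the scatter of one another, but this change gives a modest step beyond it: a 2.3-fold higher number from compound 3 to compound 4 (0.35 log units; beyond the scatter). The same holds against the unsubstituted nitrogen, with a 2.2-fold higher number from compound 1 to compound 4 (0.34 log units; beyond the scatter), while a 1.6-fold higher number from compound 2 to compound 4 (0.21 log units; within the scatter) remains within the scatter, so the position does respond to the choice of group, but only slightly across these compounds and not for every pair. No measurement shown here accounts for this modest step.

The swap from 1-amino-1-methylethyl to 1-hydroxyethyl alters the heteroatom and the carbon frame and also brings in a defined stereocentre, so the compounds shown leave open which of these differences goes with the step. A 1-hydroxy-1-methylethyl group, a 1-aminoethyl group and the opposite stereoisomer of 1-hydroxyethyl on the same carbonyl carbon would each separate one of these differences, and a carboxylic acid or a longer chain there would show how far the trend extends.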